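Thiophen-2-yl in Place of Pyridin-3-yl on a Shared Core

The source may report more compounds than this note shows. Statements on the series, on what has been measured and on what is new or still open speak of the compounds shown alone.

Measured compounds:
Compound 1 `Oc1ccc(-c2cc(-c3cccnc3)nc(-c3ccccc3Cl)c2)cc1`: 0.9%
Compound 2 `Oc1cccc(-c2cc(-c3ccc(Cl)cc3)nc(-c3cccs3)c2)c1`: 15.1%
Compound 3 `Oc1cccc(-c2cc(-c3ccncc3)nc(-c3ccccc3Cl)c2)c1`: 0%

All three compounds were tested in an assay on isolated protein for inhibition of DNA topoisomerase 1 (Homo sapiens), with a stated time of 30 min, tested at 100 uM; on this read-out lower numbers stand for a weaker effect and higher numbers for a stronger effect at the one concentration tested. Compound 1 gives 0.9%, which is the second highest of the three numbers. Compound 3 gives 0%, and the gap between compound 1 and compound 3 lies within the usual scatter, so the two cannot be told apart. Compound 2 gives 15.1%, and that number lies beyond the scatter above compound 1. Compound 2 differs from compound 1 in more than one place, so its higher number cannot be tied to any single change.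

Compound 4 `Oc1ccc(-c2cc(-c3cccs3)nc(-c3ccccc3Cl)c2)cc1` has not been measured. It differs from compound 1 in one place: thiophen-2-yl in place of pyridin-3-yl on an aromatic carbon. For the measured compounds named here, no measured pair shows this change on its own, so its effect on this assay is unknown. Going by the values given here, with all three measured numbers low and the only thiophen-2-yl compound, compound 2, also differing elsewhere, a small step is expected, if any, from compound 1 to compound 4, likely within the scatter, with the direction uncertain.

For compound 4 the expected step is a number 3.1 percentage points higher from compound 1 to compound 4 (within the scatter). The estimate for compound 4 in this assay is 4%, with a range from 0% to 18%.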

Compound 4, a percentage reported as inhibition, at one concentration (the size of the read-out at that concentration, not a potency): 2.2%
The estimate for compound 4 lay 1.8 percentage points above the measured number, and the stated range covers the measured number.
By their numbers in this assay, from the lowest: compounds 3, 1 and 4 (each within the scatter of the next); then compound 2.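

In this assay, for the compounds shown here, thiophen-2-yl in place of pyridin-3-yl on the aromatic carbon next to the ring nitrogen gives a number 1.3 percentage points higher from compound 1 to compound 4 (within the scatter), and this is the first view of that change on its own. At this position, then, a six-membered aromatic ring holding a nitrogen and a five-membered aromatic ring holding a sulfur cannot be told apart on this read-out, at least with the 4-hydroxyphenyl and 2-chlorophenyl groups kept in place. This single pair offers nothing measured that would explain why the two groups read alike.

As far as these compounds go, only these two aromatic rings have been compared at this position, so it remains open whether a non-aromatic group, such as a primary amine, a carboxylic acid or a longer alkyl chain, would move the number beyond the scatter. From the compounds shown here alone, it also remains open whether the same swap would stay this small on a core carrying a 3-hydroxyphenyl group in place of the 4-hydroxyphenyl group, since this one pair tests the change in a single setting.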